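The compounds below may be only part of what the source reports. "The series", "measured", "known", "first", "only" and "open" are said of these compounds alone.

Measured so far:
compound 1 `COc1cccc(-n2cc3nc(-c4cccnc4C)n(C[C@H]4CCCN(CC5CCCCC5)C4)c(=O)c3n2)c1` — 200 nM
compound 2 `Cc1ccccc1-c1nc2cn(-c3cccc(C#N)c3)nc2c(=O)n1CC1CCCN(C(C)C)C1` — 32 nM
compound 3 `COc1cccc(-n2cc3nc(-c4cccnc4C)n(C[C@H]4CCCN(Cc5ccco5)C4)c(=O)c3n2)c1` — 2.7 nM

All three were tested in an assay on HEK293 cells for displacement of a labelled ligand from growth hormone secretagogue receptor type 1 (Homo sapiens), with a stated time of 60 min; a lower number here means a stronger inhibitor, a higher number a weaker inhibitor. Among them compound 2 stands second highest: compound 1 gives a higher number than compound 2 does, while compound 3 gives a lower number than compound 2 does, and both gaps lie beyond the scatter. Among the compounds with values here, the one step between measured compounds differing in a single place is a 74-fold lower number from compound 1 to compound 3 (1.87 log units; beyond the scatter), which concerns the group on the saturated chain carbon attached to the ring amine.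

Compound 4 `Cc1ccccc1-c1nc2cn(-c3ccc(Cl)cc3)nc2c(=O)n1CC1CCCN(C(C)C)C1` differs from compound 2 in another place: 4-chlorophenyl in place of 3-cyanophenyl on an aromatic nitrogen. Within the data shown here, no measured step here changes the group on that aromatic nitrogen, so the step to compound 4 is not covered by the data; the large step from compound 1 to compound 3 sits elsewhere in the molecule and says nothing direct about it. With no comparison to lean on, the step in this assay is expected to be small, in no clear direction, and may well fall within the scatter, so a 1.3-fold higher number from compound 2 to compound 4 (0.10 log units; within the scatter) is the estimate. Compound 4 is therefore expected to give about 40 nM in this assay, most likely between 10 nM and 160 nM.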

Compound 4, half-maximal inhibitory concentration in the growth hormone secretagogue receptor type 1 assay: 0.28 nM
For compound 4 the middle estimate is 140-fold (2.15 log units) above the measured one; the measured number lies below the stated range.
By their numbers in the growth hormone secretagogue receptor type 1 assay, from the lowest: compound 4; then compound 3; then compound 2; then compound 1.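

The group on this aromatic nitrogen turns out to be a strong lever: in the growth hormone secretagogue receptor type 1 assay the change gives a 110-fold lower number from compound 2 to compound 4 (2.06 log units; beyond the scatter), with compound 2 at 32 nM and compound 4 at 0.28 nM. Within the data shown here, until now, the only large step was at the other end of the molecule, the one on the saturated chain carbon, with a 74-fold lower number from compound 1 to compound 3 (1.87 log units; beyond the scatter), and both steps count as large. In a physicochemical assay for acid dissociation, compound 2 gives 9.9 and compound 4 gives 10; the same change gives a number 0.10 log units higher from compound 2 to compound 4 (within the scatter), so that read-out does not separate the two compounds, even though the binding numbers lie far apart.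

On these data alone, the change does several things at once: the nitrile leaves, taking its one hydrogen-bond acceptor with it, chlorine enters, and the group's ring position differs, so 3-chlorophenyl or 4-cyanophenyl on the same nitrogen would be needed to pull these apart, and whether a 4-aminophenyl or 4-carboxyphenyl group is tolerated there stays open as well. Nothing measured here gives a reason for the size of this step.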